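A few compounds are considered here, and "the series" means these few. Any claim that something is new, unique, unknown or untested is made for them only; others in the source may bear on it.

Compound 1 `CSc1ccccc1N1C(N)=NC(N)=NC1(C)C` gives 3.91 in an assay for inhibition of Dihydrofolate reductase (Bos taurus), at pH 7.20; a lower number here means a less potent compound, a higher number a more potent compound, by a factor of ten per unit of this negative logarithm. Compound 2 `CC1(C)N=C(N)N=C(N)N1c1ccccc1F` gives 5.41 in this assay. Compound 3 `CCc1ccccc1N1C(N)=NC(N)=NC1(C)C` gives 4.48 in this assay.

Compound 3 stands second highest of these three numbers. Its nearest neighbour is compound 1, with the number a number 0.57 log units higher from compound 1 to compound 3 (beyond the scatter); the step of a number 0.93 log units lower from compound 2 to compound 3 (beyond the scatter) places compound 2 furthest from it. Compound 4 `CC1(C)N=C(N)N=C(N)N1c1ccccc1Cl` differs from compound 3 at one point: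

chloro in place of ethyl on an aromatic carbon

Going by the values given here, two measured steps bear on this change. The step of a number 0.93 log units lower from compound 2 to compound 3 (beyond the scatter) shows that a halogen, fluoro, on this aromatic carbon gives a clearly higher number than ethyl, and a number 1.50 log units higher from compound 1 to compound 2 (beyond the scatter) shows fluoro well above methylsulfanyl. Chloro is a halogen like fluoro, yet no chloro compound has been measured, so the expectation is tentative. A rise from compound 3 is expected, of a modest size, since compound 3 itself lies above compound 1 by a number 0.57 log units higher from compound 1 to compound 3 (beyond the scatter). In this assay compound 4 is therefore expected to give about 5.1, with a range from 4.5 to 5.7, a step of a number 0.62 log units higher from compound 3 to compound 4 (beyond the scatter).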

Compound 4, logarithm of the reciprocal of the active concentration, log(1/C): 5.19
Compound 4: middle estimate off by 0.09 log units, on the low side; measured number inside the range.
By their numbers in this assay, from the lowest: compound 1; then compound 3; then compounds 4 and 2 (each within the scatter of the next).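

Chloro in place of ethyl gives a number 0.71 log units higher from compound 3 to compound 4 (beyond the scatter), so the rise over ethyl seen with fluoro is not limited to fluoro but also appears with a second halogen. Chloro in place of fluoro gives a number 0.22 log units lower from compound 2 to compound 4 (within the scatter), so this assay does not separate these two halogens at this position. Chloro in place of methylsulfanyl gives a number 1.28 log units higher from compound 1 to compound 4 (beyond the scatter), and among these four compounds both halogens therefore stand clear of ethyl and methylsulfanyl.

No measurement at hand explains this order of the groups. The compounds shown leave open whether bromo or an amine on this aromatic carbon would stay level with the two halogens or fall towards ethyl and methylsulfanyl.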